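A few compounds are considered here, and "the series" means these few. Any claim that something is new, unique, unknown or untested is made for them only; others in the source may bear on it.

Measured in an in vitro functional assay on cells for agonist activity at Bombesin receptor subtype-3 (Homo sapiens), read by luminescence and calcium flux; on this read-out higher numbers stand for an effect only at larger amounts of compound and lower numbers for an effect already at smaller amounts:
Compound 1, `O=C(O)c1ccccc1-c1ccc(CCc2ncc(CC3CCOCC3)[nH]2)cc1`, gives 338 nM.
Compound 2, `CCC(C)(C)Cc1c[nH]c(CCc2ccc(-c3ccccc3C(=O)O)cc2)n1`, gives 25 nM.

Of these two numbers, compound 1 has the higher one, and its gap from compound 2 lies beyond the scatter. Compound 3, `O=C(O)c1ccccc1-c1ccc(CCc2ncc(CCC3CCCCC3)[nH]2)cc1`, has not yet been measured in this assay. It differs from compound 1 by cyclohexylmethyl in place of oxan-4-yl on a saturated chain carbon bound to an aromatic carbon. Compound 2 carries a different saturated side chain on the shared core and gives 25 nM, so compound 3 is expected to move toward a lower number, with an estimated step of a 4.8-fold lower number from compound 1 to compound 3 (0.68 log units; beyond the scatter). Compound 3 is accordingly estimated at 70 nM, within a range from 20 nM to 250 nM.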

Compound 3, half-maximal effective concentration: 642 nM
Beside the measured number, compound 3's estimate is 9.2-fold (0.96 log units) below it; the measured number lies above the stated range.
By their numbers in this assay, from the lowest: compound 2; then compounds 1 and 3 (each within the scatter of the next).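

In this assay, cyclohexylmethyl in place of oxan-4-yl on a saturated chain carbon bound to an aromatic carbon gives a 1.9-fold higher number from compound 1 to compound 3 (0.28 log units; within the scatter), so removing the ring oxygen and extending the side chain by one carbon together leave the read-out within the scatter. A carbon-only ring at this place therefore does not reach the number of compound 2, at 25 nM. Nothing available here explains this result. Going by these compounds, it remains open how an amine such as piperidin-4-yl would read in place of oxan-4-yl, and whether the two changes in compound 3 would behave alike if taken separately.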